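Moving the carboxylate and swapping chlorine for fluorine

This account rests on a few compounds, and the source may have more. Where it says the series, first, only, none or still open, it means among the compounds named here.

The compounds measured so far:
Compound 1, `Cc1c(OCCCCOc2cncc(C(=O)O)c2)ccc(C(=O)CC(C)(C)C)c1O`, in an assay for positive allosteric modulation of metabotropic glutamate receptor 3 (Rattus norvegicus) (a higher number here means that more compound is needed for the effect, a lower number that less compound is needed), compound 1 gives 180 nM.
Compound 2, `COc1cc(OCCCCOc2ccc(C(=O)CC(C)(C)C)c(O)c2C)cc(C(=O)O)c1`, in this assay compound 2 gives 703 nM.
Compound 3, `Cc1c(OC[C@@H](C)COc2ccc(Cl)c(C(=O)O)c2)ccc(C(=O)CC(C)(C)C)c1O`, in this assay compound 3 gives 2200 nM.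

Compound 3 stands at the highest number of the three, beyond the scatter from both compound 2 and compound 1, so among these three it needs the most material to reach the half-maximal effect. Compound 4, `Cc1c(OC[C@@H](C)COc2ccc(C(=O)O)c(F)c2)ccc(C(=O)CC(C)(C)C)c1O`, keeps the shared core and the branched linker of compound 3 and differs only in the aryl group at its far end: 4-carboxy-3-fluorophenyl in place of 3-carboxy-4-chlorophenyl on an oxygen on a saturated carbon. In words, 4-carboxy-3-fluorophenyl replaces 3-carboxy-4-chlorophenyl on an oxygen on a saturated carbon.

Within the data shown here, no pair of measured compounds differs in exactly this way, so there is no directly comparable step. The counted difference leaves the size of the group and its donor and acceptor count unchanged, and what is exchanged is the halogen and the seat of the carboxylic acid on the ring. On that basis the expected step from compound 3 to compound 4 in this assay, a 1.5-fold lower number from compound 3 to compound 4 (0.17 log units; within the scatter), is a modest move towards a lower number, of a size that may not exceed the scatter. Compound 4 is accordingly estimated at 1500 nM, with a range from 500 nM to 5000 nM.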

Compound 4, half-maximal effective concentration: 1090 nM
The estimate for compound 4 lay 1.4-fold (0.14 log units) above the measured number; measured number inside the range.
By their numbers in this assay, from the lowest: compound 1; then compounds 2, 4 and 3 (each within the scatter of the next, the first and the last beyond it).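

In this assay, the exchange of 3-carboxy-4-chlorophenyl for 4-carboxy-3-fluorophenyl on an oxygen on a saturated carbon comes to a 2.0-fold lower number from compound 3 to compound 4 (0.30 log units; within the scatter), so at this position the two aryl groups cannot be told apart by their numbers. Among these compounds, this is the first pair in the set that differs in one place, and it shows that altering the halogen and the seat of the carboxylic acid together, with the size of the group and its donor and acceptor count unchanged, does not carry the number beyond the scatter. Nothing at hand explains this outcome, and no measurement bears on why the two groups read alike.

The step changes the halogen and the seat of the acid at once, so it leaves open whether each change alone would also stay within the scatter or whether the two contributions merely cancel. That could be read from 3-carboxy-4-fluorophenyl or 4-carboxy-3-chlorophenyl at the same place, while plain 4-carboxyphenyl, with no halogen, would show what the fluorine itself contributes.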